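The source may report more compounds than this note shows. Statements on the series, on what has been measured and on what is new or still open speak of the compounds shown alone.

Measured in a functional assay on NCI-H460 cells (Homo sapiens) for inhibition, read by MTT assay, with a stated time of 72 h; on this read-out higher numbers stand for weaker inhibition and lower numbers for stronger inhibition:
compound 1 `COc1cc(NC(C)CCCNC(=O)NNC(=O)Nc2cccc(F)c2)c2ncccc2c1`: 50000 nM
compound 2 `COc1cc(NC(C)CCCNC(=O)Nc2ccc(C(F)(F)F)cc2)c2ncccc2c1`: 24000 nM
compound 3 `COc1cc(NC(C)CCCNC(=O)Nc2cccc(F)c2)c2ncccc2c1`: 24000 nM

Compound 3 stands level with compound 2 at the digits printed, and the two of them give the lowest numbers of the three. Compound 1 is the furthest away: a 2.1-fold lower number from compound 1 to compound 3 (0.32 log units; beyond the scatter). The same kind of step appears in a 2.1-fold lower number from compound 1 to compound 2 (0.32 log units; beyond the scatter). Between the two aryl ureas themselves there is nothing to separate: no change at the digits printed from compound 2 to compound 3 (within the scatter).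

Going by the values given here, compound 4 `COc1cc(NC(C)CCCNC(=O)Nc2ccc(Br)cc2)c2ncccc2c1` has not yet been measured. 4-bromophenyl in place of 3-fluorophenyl on an amide-type nitrogen Only one measured step bears on this kind of exchange, the aryl-for-aryl swap between compound 2 and compound 3, which stayed within the scatter. Among the compounds with values here, there is no measured compound carrying the 4-bromophenyl group itself, so the expectation rests on that single comparison. Compound 4 is therefore expected to give roughly 24000 nM, with a range of 10000 nM to 55000 nM. The expected step is no change at the digits printed from compound 3 to compound 4 (within the scatter), that is, no change beyond the scatter.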

Compound 4, half-maximal inhibitory concentration: 30000 nM
For compound 4 the middle estimate is 1.3-fold (0.10 log units) below the measured one; the measured number falls inside the stated range.
By their numbers in this assay, from the lowest: compounds 2, 3, 4 and 1 (each within the scatter of the next, the first and the last beyond it).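

Compound 4 adds a third aryl group on the amide-type nitrogen, and the 4-bromophenyl group reads level with both earlier ones: a 1.3-fold higher number from compound 3 to compound 4 (0.10 log units; within the scatter) and a 1.3-fold higher number from compound 2 to compound 4 (0.10 log units; within the scatter). The second of these steps also shows that bromo in place of trifluoromethyl on an aromatic carbon leaves the number within the scatter. The gap to the ((3-fluorophenyl)carbamoyl)amino compound is less clear here than for the other two aryl ureas, with a 1.7-fold lower number from compound 1 to compound 4 (0.22 log units; within the scatter), and no measurement available explains how these groups compare.

Open, as far as these compounds go, is whether an aryl group carrying an amine or a carboxylic acid, or a longer chain on the shared core, would move the number beyond the scatter from compound 3. Also open, from the compounds shown here alone, is how 4-fluorophenyl would read, since group and ring position change together from compound 3 to compound 4.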